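This account rests on a few compounds, and the source may have more. Where it says the series, first, only, none or still open, it means among the compounds named here.

Compound 1 `CCCCC[Se]c1nc([Se]CCCCC)c2ccccc2n1` in a functional assay on CCRF-CEM cells (Homo sapiens) for cytotoxicity, read by MTT assay, with a stated time of 72 h (a higher number here means that more compound is tolerated, a lower number that less compound is tolerated), gives > 100000 nM, a limit of the assay. Compound 2 `CCCCC[Se]c1nc(NCc2ccccc2)c2ccccc2n1` gives in this assay > 100000 nM, also a limit. Compound 3 `C[Se]c1nc(NCc2ccccc2)c2ccccc2n1` gives in this assay 83500 nM.

Compound 2 thus stands at the limit of > 100000 nM in this assay, at which 2 of the 3 values shown sit, with no number of its own. Compound 4 `CCCCC[Se]c1nc(N)c2ccccc2n1` differs from compound 2 by hydrogen in place of benzyl on a nitrogen on an aromatic ring, benzylamino to amino. Neither measured step touches this nitrogen: a step that the two limits leave unreadable from compound 1 to compound 2 swaps a different group, and an at least 1.1-fold lower number from compound 2 to compound 3 (0.07 log units; that floor lies within the scatter) shortens the chain on selenium. So no step beyond the scatter in either direction is expected in this assay. Compound 4 is expected near 100000 nM, between 40000 nM and 300000 nM, an expected step of a number no higher from compound 2 to compound 4 (the limit leaves the size open).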

Compound 4, concentration lethal to 50% of the cells: > 100000 nM
Compound 4 ended at the assay's limit; the forecaster's own chance of this, stated with the estimate: 60%; the middle value sits exactly at the limit.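

In this assay compound 4 gives > 100000 nM, a limit of the assay. For the compounds shown here, no step from compound 1 or compound 2 to compound 4 can be read. The compounds shown leave open how far benzylamino to amino moves the number: the limit of > 100000 nM in this assay, at which 3 of the 4 values shown sit.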